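This account rests on a few compounds, and the source may have more. Where it says the series, first, only, none or still open, it means among the compounds named here.

The compounds with numbers so far:

Compound 1, `CCOC(=O)c1c(-c2cc3cc(OC)ccc3oc2=O)nn(-c2ccccc2)c1C(=O)OCC`: in a functional assay on HeLa cells (Homo sapiens) for cytotoxicity, read by MTT assay, with a stated time of 48 h (a higher number here means a weaker inhibitor, a lower number a stronger inhibitor), compound 1 gives 145000 nM.
Compound 2, `CCOC(=O)c1c(-c2cc3cc(OC)ccc3oc2=O)nn(-c2cccc(C)c2)c1C(=O)OCC`: in this assay compound 2 gives 155000 nM.

Going by the values given here, compound 2 holds the higher of the two numbers, and its only neighbour is compound 1; the gap between them, a 1.1-fold higher number from compound 1 to compound 2 (0.03 log units; within the scatter), lies within the scatter, so the two compounds cannot be told apart by these numbers.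

Compound 3, `CCOC(=O)c1c(-c2cc3cc(OC)ccc3oc2=O)nn(-c2cccc(Cl)c2)c1C(=O)OCC`, differs from compound 2 by chloro in place of methyl on an aromatic carbon. Among the compounds with values here, the one measured step, a 1.1-fold higher number from compound 1 to compound 2 (0.03 log units; within the scatter), changed the same ring position by putting methyl in place of hydrogen and moved the number by no more than the scatter. Within the data shown here, no measured pair shows chloro in place of methyl, so there is nothing that speaks directly to this change. Given that the only step at this position was flat, compound 3 is expected to show a step of about a 1.0-fold lower number from compound 2 to compound 3 (0.01 log units; within the scatter) in this assay, which is no step beyond the scatter. Compound 3 is therefore estimated at 150000 nM, with a range from 70000 nM to 320000 nM.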

Compound 3, half-maximal inhibitory concentration: 160000 nM
For compound 3 the middle estimate is 1.1-fold (0.03 log units) below the measured one; the measured number falls inside the stated range.
By their numbers in this assay, from the lowest: compounds 1, 2 and 3 (each within the scatter of the next).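

In this assay, going by these compounds alone, the step of a 1.0-fold higher number from compound 2 to compound 3 (0.01 log units; within the scatter) is the first comparison of two different substituents at this position on the phenyl ring, and it lies within the scatter. The step of a 1.1-fold higher number from compound 1 to compound 3 (0.04 log units; within the scatter) adds that chloro in place of hydrogen, like methyl in place of hydrogen before it, also stays within the scatter, so hydrogen, methyl and chloro at this one position cannot be told apart by these numbers. No outside evidence is available to bear on this result.

As far as these compounds go, all three compounds carry the same shared core and the same two ethyl esters, and the only substituents compared are methyl and chloro at a single ring position, so it remains open whether this position would stay as insensitive with an amine, a carboxylic acid or a longer chain there. From the compounds shown here alone, it also remains open whether methyl or chloro would read the same at another position on the phenyl ring, and whether any change to the esters would shift the number beyond the scatter.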